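Cytotoxicity notes on aryl thioureas in MDBK cells

A few compounds are considered here, and "the series" means these few. Any claim that something is new, unique, unknown or untested is made for them only; others in the source may bear on it.

Measured so far:
compound 1, `C=C(C)CNC(=S)Nc1cccc(C(F)(F)F)c1`: > 100000 nM
compound 2, `CCCCc1ccc(NC(=S)Nc2cccc(C(F)(F)F)c2)c(C)c1`: 10000 nM
compound 3, `CC[C@H]1CC[C@H](c2ccc(NC(=S)Nc3cccc(C(F)(F)F)c3)cc2)CC1`: 9000 nM

In an ADME assay on MDBK cells (Bos taurus) for cytotoxicity, read by MTT assay, with a stated time of 96 h (a lower number here means that less compound is tolerated, a higher number that more compound is tolerated), compound 1 gives only a limit, > 100000 nM, and no number. Compound 2 gives 10000 nM in this assay. Compound 3 gives 9000 nM, the lowest of the two numbers in this assay; its nearest neighbour is compound 2, and the two values lie within the scatter of each other, so no order between them is claimed. The unmeasured compound 4, `O=[N+]([O-])c1ccc(NC(=S)Nc2cccc(C(F)(F)F)c2)cc1`, carries nitro in place of 4-ethylcyclohexyl on an aromatic carbon.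

For the measured compounds named here, no step between two measured compounds is available, so the size of the change from compound 3 can only be expected, not read from a precedent. The exchange is large, as the count shows, and the smaller, more polar entering group gives no ground to expect a lower number. Compound 4 is expected to be tolerated somewhat better than compound 3, with the step expected as a 3.9-fold higher number from compound 3 to compound 4 (0.59 log units; beyond the scatter). For compound 4 the estimate in this assay is 35000 nM, with a range from 9000 nM to 100000 nM.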

Compound 4, half-maximal cytotoxic concentration: 10000 nM
For compound 4 the middle estimate is 3.5-fold (0.54 log units) above the measured one; the measured number falls inside the stated range.
By their numbers in this assay, from the lowest: compounds 3, 2 and 4 (each within the scatter of the next). At a limit, above all of these: compound 1.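

In this assay the series now has its first readable step, a 1.1-fold higher number from compound 3 to compound 4 (0.05 log units; within the scatter), with nitro in place of 4-ethylcyclohexyl on an aromatic carbon. The leaving and entering groups differ in ring, heavy-atom count and hydrogen-bond acceptors, yet this read-out does not separate them at this position, para to a large group. Neither compound 3 nor compound 4 stands at a limit, so this step compares two numbers, while compound 1 gives only a limit: the limit of > 100000 nM in this assay, at which 1 of the 4 values shown sits.

Going by these compounds, whether an amine, a carboxylic acid or a longer alkyl chain at this position would also leave the number within the scatter remains open. Also open, on these data alone, is whether a chlorine or a methoxy group in place of trifluoromethyl would shift the number.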